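Swapping the aryl group on a shared kinase-binding core

A few compounds are considered here, and "the series" means these few. Any claim that something is new, unique, unknown or untested is made for them only; others in the source may bear on it.

Measured compounds:
Compound 1, `CCCS(=O)(=O)Nc1ccc(F)c(C(=O)c2n[nH]c3ncc(-c4ccc(F)cc4)cc23)c1F`, gives 2.1% in an assay for binding affinity to dual specificity mitogen-activated protein kinase kinase 4 (Homo sapiens), read by KINOMEscan, tested at 100 nM; on this read-out lower numbers stand for a stronger effect and higher numbers for a weaker effect at the one concentration tested.
Compound 2, `CCCS(=O)(=O)Nc1ccc(F)c(C(=O)c2n[nH]c3ncc(-c4ccc(C)cc4)cc23)c1F`, gives 5.4% in this assay.
Compound 3, `CCCS(=O)(=O)Nc1ccc(F)c(C(=O)c2n[nH]c3ncc(-c4ccccc4OC)cc23)c1F`, gives 1.9% in this assay.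

All three compounds share the same core and differ only in the aryl group attached to it. Their numbers sit close together: the step of a number 3.3 percentage points higher from compound 1 to compound 2 (within the scatter), the step of a number 0.2 percentage points lower from compound 1 to compound 3 (within the scatter) and the step of a number 3.5 percentage points lower from compound 2 to compound 3 (within the scatter) all lie within the scatter, so none of the three can be set apart from the others. Compound 3 stands among them with a small number, indistinguishable from compound 1 and compound 2.

Compound 4, `CCCS(=O)(=O)Nc1ccc(F)c(C(=O)c2n[nH]c3ncc(-c4ccc(O)cc4)cc23)c1F`, has not yet been measured. It differs from compound 3 as follows: 4-hydroxyphenyl in place of 2-methoxyphenyl on an aromatic carbon. The measured steps that bear on this are the three exchanges of the aryl group already described, and none of them moved the read-out beyond the scatter. On that basis the change to compound 4 is expected to give a number 1.6 percentage points higher from compound 3 to compound 4 (within the scatter), a step of no meaningful size in either direction. Compound 4 is therefore estimated to give 3.5% in this assay, with a range from 0.5% to 12%.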

Compound 4, a percentage reported as activity, at one concentration (the size of the read-out at that concentration, not a potency): 0.75%
The estimate for compound 4 lay 2.8 percentage points above the measured number, and the stated range covers the measured number.
By their numbers in this assay, from the lowest: compounds 4, 3, 1 and 2 (each within the scatter of the next).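

Of the four aryl groups, only the 4-hydroxyphenyl of compound 4 carries a hydrogen-bond donor, and exchanging the 2-methoxyphenyl of compound 3 for it gives a number 1.2 percentage points lower from compound 3 to compound 4 (within the scatter) in this assay. Placing hydroxy where the other two compounds carry methyl or fluoro gives a number 4.7 percentage points lower from compound 2 to compound 4 (within the scatter) and a number 1.4 percentage points lower from compound 1 to compound 4 (within the scatter) on the same read-out, so at this place on the shared core a hydroxy group reads the same as methyl and fluoro, and the group adds a new kind of substituent to the three already shown without setting any compound apart. Nothing on hand explains why these four aryl groups read alike.

As far as these compounds go, all four groups attached here are six-membered carbon rings, so it remains open whether the position also accepts a phenyl ring bearing a carboxylic acid or an amine, a pyridine ring, or a plain alkyl chain in place of the ring. From the compounds shown here alone, it also remains open whether compounds that cannot be told apart at one concentration would separate in a full potency measurement.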